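Chloro on the shared core: notes on growth inhibition

The source may report more compounds than this note shows. Statements on the series, on what has been measured and on what is new or still open speak of the compounds shown alone.

Three compounds have values in a functional assay on HCC 2998 cells (Homo sapiens) for antiproliferative activity; on this read-out lower numbers stand for stronger inhibition of growth and higher numbers for weaker inhibition of growth. Compound 1 (`COc1ccc(-c2nc3ccccc3s2)cc1OC`) gives 42500 nM and compound 3 (`COCOc1ccc(-c2nc3cc(F)ccc3s2)cc1OC`) gives 53500 nM, so these two lie within the scatter of each other. Compound 2 (`COc1ccc(-c2nc3cc(F)ccc3s2)cc1Br`) gives 3450 nM, well beyond the scatter on the lower side of compound 1. Compound 1 therefore sits at the weak end of this small set, alongside compound 3.

Compound 4 (`COc1ccc(-c2nc3cc(Cl)ccc3s2)cc1OC`) differs from compound 1 in one place: chloro in place of hydrogen on an aromatic carbon. Going by the values given here, no pair of measured compounds differs by a single change, so this step has no direct precedent.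

Among the compounds with values here, the only guidance is indirect. Compound 2 at 3450 nM and compound 3 at 53500 nM both carry a fluoro on the core, yet they sit far apart, so a halogen there does not settle the outcome. A modest move towards a lower number is expected, and it may not clear the scatter. The estimated change is a 2.1-fold lower number from compound 1 to compound 4 (0.33 log units; beyond the scatter). For compound 4 the estimate is 20000 nM, with an expected range from 5000 nM to 70000 nM.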

Compound 4, concentration for 50% growth inhibition: 4880 nM
The estimate for compound 4 lay 4.1-fold (0.61 log units) above the measured number; measured number outside the range, below it.
By their numbers in this assay, from the lowest: compounds 2 and 4 (each within the scatter of the next); then compounds 1 and 3 (each within the scatter of the next).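

Chloro in place of hydrogen on an aromatic carbon gives, in this assay, an 8.7-fold lower number from compound 1 to compound 4 (0.94 log units; beyond the scatter), the first single-change step in the series and one that lies beyond the scatter. This position, on a six-membered aromatic ring of carbon only that is part of a fused or bridged system of two rings, meta to a fused ring and para to a fused ring, therefore responds to substitution: one chlorine atom, with the rest of compound 1 unchanged, is enough to shift growth inhibition clearly towards lower numbers. Nothing available bears on why this step has the size it has, and the result stands as an observation only.

From the compounds shown here alone, one pair gives one step, so it remains open whether the shift is particular to chloro or would also appear with another group at this place, such as methyl, nitrile or an amine. Going by these compounds, it is also open whether the same step would have a similar size with different groups elsewhere on the shared core, as a single pair cannot show how far it carries over.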